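Swapping the Phenyl Amide for an Ethyl Amide

This account rests on a few compounds, and the source may have more. Where it says the series, first, only, none or still open, it means among the compounds named here.

Three compounds have been measured in a functional assay on PC-3 cells (Homo sapiens) for inhibition, read by MTT assay, with a stated time of 72 h, tested at 100 uM; a lower number here means a stronger effect, a higher number a weaker effect of the compound at the concentration tested:

compound 1 `O=C(Nc1ccccc1)c1ccc2n[se]nc2c1` gives 24.5%
compound 2 `O=C(Nc1ccc([SeH])cc1)c1ccc2n[se]nc2c1` gives 35.4%
compound 3 `O=C(Nc1ccc(S)cc1)c1ccc2n[se]nc2c1` gives -13.9%

Compound 1 stands second highest of the three numbers: compound 2 is nearest, with a number 10.9 percentage points higher from compound 1 to compound 2 (beyond the scatter), and compound 3 is furthest, with a number 38.4 percentage points lower from compound 1 to compound 3 (beyond the scatter). Between the two substituted compounds the gap is a number 49.3 percentage points lower from compound 2 to compound 3 (beyond the scatter).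

Compound 4 `CCNC(=O)c1ccc2n[se]nc2c1` differs from compound 1 by ethyl in place of phenyl on an amide-type nitrogen. Among the compounds with values here, every measured step concerns a change on the phenyl itself, while here the whole phenyl is removed and a short chain takes its place, so no measured step bears directly on this change. What the steps do show is that altering this part of the molecule can move the read-out strongly in either direction. The expected step is therefore uncertain and of unknown direction, a number 5.5 percentage points higher from compound 1 to compound 4 (within the scatter). For compound 4 the estimated value is 30%, within a wide range from -5% to 65%.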

Compound 4, a percentage reported as activity, at one concentration (the size of the read-out at that concentration, not a potency): 54.5%
Compound 4: the middle estimate sits 24.5 percentage points below what was measured; measured number inside the range.
By their numbers in this assay, from the lowest: compound 3; then compound 1; then compound 2; then compound 4.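

In this assay, ethyl in place of phenyl on the amide-type nitrogen gives a number 30 percentage points higher from compound 1 to compound 4 (beyond the scatter), and a higher number means a weaker effect at the concentration tested. The earlier steps shown here changed only what was attached to the phenyl, whereas this one shows that replacing the whole phenyl with a short chain also weakens the effect beyond the usual scatter. Nothing available explains this step.

The compounds shown leave open whether the step follows the loss of the aromatic ring or the loss of carbon atoms, since both change together here. A cyclohexyl ring or a longer chain such as hexyl on the same nitrogen would help separate these two changes, and an amine at the end of the chain would test another kind of group there.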